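Swapping a Sulfonamide Arm for a Butyl Chain

The source may hold more compounds than are shown below. What is called first, only, known or untested is meant among the compounds shown, and "the series" means these compounds.

Compound 1 `Cc1ccc(S(=O)(=O)NCc2cn(C[C@H](O)[C@H]3OC(=O)C(OCc4ccccc4)=C3OCc3ccccc3)nn2)cc1` gives 45800 nM in a functional assay on SW-620 cells (Homo sapiens) for antiproliferative activity, read by MTT assay, with a stated time of 72 h; a lower number here means a stronger inhibitor, a higher number a weaker inhibitor.
Compound 3 `O=C1O[C@H]([C@@H](O)Cn2cc(CNS(=O)(=O)c3ccc(Cl)cc3)nn2)C(OCc2ccccc2)=C1OCc1ccccc1` gives 18000 nM in this assay.
Compound 2 `COc1ccccc1-c1cn(C/C=C2\OC(=O)C(OCc3ccccc3)=C2OCc2ccccc2)nn1` reaches only > 100000 nM in this assay, and that is a limit of the measurement, not a number.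

Among the two numbers actually reached, compound 1 holds the highest and so is the weaker of the two measured inhibitors; compound 3 sits nearest to it. Among the compounds with values here, the only change measured one place at a time is a 2.5-fold lower number from compound 1 to compound 3 (0.41 log units; beyond the scatter), a modest move.

Compound 4 `CCCCc1cn(C[C@H](O)[C@H]2OC(=O)C(OCc3ccccc3)=C2OCc2ccccc2)nn1` has not yet been tested in this assay. It differs from compound 1 by propyl in place of ((4-methylphenyl)sulfonyl)amino on a saturated chain carbon bound to an aromatic carbon. The measured step of a 2.5-fold lower number from compound 1 to compound 3 (0.41 log units; beyond the scatter) touches only a substituent on the aromatic ring that is removed here, so it bears loosely on the present change: it shows that small edits within this arm shift the number modestly. Within the data shown here, no measured pair shows the whole sulfonamide arm being cut away while the shared core is kept.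

Compound 4 is therefore expected to land near compound 1, with wide uncertainty in either direction. The expected step is a 1.1-fold higher number from compound 1 to compound 4 (0.04 log units; within the scatter). The estimate for compound 4 is 50000 nM, in the range 15000 nM to 150000 nM.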

Compound 4, half-maximal inhibitory concentration: 47500 nM
Compound 4: middle estimate off by 1.1-fold (0.02 log units), on the high side; the measured number falls inside the stated range.
By their numbers in this assay, from the lowest: compound 3; then compounds 1 and 4 (each within the scatter of the next). At a limit, above all of these: compound 2.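

In this assay there is a 1.0-fold higher number from compound 1 to compound 4 (0.02 log units; within the scatter) when the ((4-methylphenyl)sulfonyl)amino group, aromatic ring and all, gives way to propyl, so in this one case the large group can be replaced by a small plain chain with no readable change in the number. The same replacement starting from the chloro analogue reads differently: there is a 2.6-fold higher number from compound 3 to compound 4 (0.42 log units; beyond the scatter) when ((4-chlorophenyl)sulfonyl)amino gives way to propyl, so the sulfonamide arm beats the plain chain only in the form that carries chloro, a modest edge, while the form that carries methyl does not. Nothing measured here accounts for either step.

The compounds shown leave open whether the length of the plain chain matters, for instance whether a methyl or an octyl group in place of the butyl chain would shift the number at all. They also leave open whether a chain ending in an amine or a carboxylic acid behaves like butyl, and whether other ring substituents, such as fluoro or methoxy, match the edge seen with chloro.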